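Five-membered ring swap on compound 1

This account rests on a few compounds, and the source may have more. Where it says the series, first, only, none or still open, it means among the compounds named here.

For the measured compounds named here, compound 1 `Cn1nc2c(=O)n(CC3(O)CCN(Cc4ccc(-c5n[nH]c(=O)o5)cc4Cl)CC3)cnc2c1-c1ccc(CN)cc1` stands at the weaker end of the two numbers in hand: in an assay on isolated protein for inhibition of ubiquitin carboxyl-terminal hydrolase 7 (Homo sapiens), with stated times of 30 min and 2 h (on this read-out lower numbers stand for stronger inhibition and higher numbers for weaker inhibition), compound 1 gives 171 nM, while compound 2 `Cn1nc2c(=O)n(CC3(O)CCN(Cc4ccc(-c5ccco5)cc4Cl)CC3)cnc2c1-c1ccc(F)cc1` gives 64.5 nM, a gap beyond the scatter, though compound 2 differs from compound 1 in more than one group, so no single step is isolated. Compound 3 `Cn1nc2c(=O)n(CC3(O)CCN(Cc4ccc(-n5cccn5)cc4Cl)CC3)cnc2c1-c1ccc(CN)cc1` keeps the core of compound 1 and changes one group: a group of 5 heavy atoms (3 carbon, 2 nitrogen; one five-membered aromatic ring with 2 hetero atoms) in place of a group of 6 heavy atoms (2 carbon, 2 nitrogen, 2 oxygen; one five-membered aromatic ring with 3 hetero atoms), on an aromatic carbon. Going by the values given here, with no measured step of this kind, the expectation for compound 3 is a small shift, a 1.3-fold lower number from compound 1 to compound 3 (0.12 log units; within the scatter), toward a lower number and not clearly beyond the scatter. Compound 3 is therefore estimated at 130 nM, range 45 nM to 380 nM.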

Compound 3, half-maximal inhibitory concentration: 233 nM
The estimate for compound 3 lay 1.8-fold (0.25 log units) below the measured number, and the stated range covers the measured number.
By their numbers in this assay, from the lowest: compound 2; then compounds 1 and 3 (each within the scatter of the next).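

At this position, para to a large group and meta to a chloro group, the 1H-pyrazol-1-yl ring replaces the larger ring with a 1.4-fold higher number from compound 1 to compound 3 (0.13 log units; within the scatter), so the two compounds cannot be told apart. In this pair, then, the hydrogen-bond donor and the carbonyl of the leaving ring are not needed to hold the number within the scatter. Nothing available explains this result.

On these data alone, whether a carboxylic acid or a simple phenyl ring at this position would also be tolerated remains open. As far as these compounds go, how the gap to compound 2 divides between its furan ring and its fluoro group also remains open.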